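A sulfonamide series sitting at its assay limit

The compounds below may be only part of what the source reports. "The series", "measured", "known", "first", "only" and "open" are said of these compounds alone.

Of the compounds shown here, three sharing one core have been tested in a functional assay on cells (leukaemia cell line, Homo sapiens) for inhibition, read by sulforhodamine B assay, with a stated time of 48 h (a lower number here means that less compound is tolerated, a higher number that more compound is tolerated), and none has yet given a number. Compound 1 `O=S(=O)(Nc1ccc(Cl)c(Cl)c1)c1ccc(-c2cnc(C3CC3)o2)cc1` gives > 100000 nM as a limit of the assay, not a number. Compound 2 `O=S(=O)(Nc1ccc(Cl)cc1Cl)c1ccc(-c2cnc(C3CC3)o2)cc1` gives > 100000 nM as a limit too. Compound 3 `Cc1cc(Cl)ccc1NS(=O)(=O)c1ccc(-c2cnc(C3CC3)o2)cc1` gives > 100000 nM as a limit as well. Compound 3 therefore has no number of its own to start from, and the set shows only the limit of > 100000 nM in this assay, at which 3 of the 3 values shown sit, here.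

Compound 4 `O=S(=O)(Nc1ccc(I)c(Cl)c1)c1ccc(-c2cnc(C3CC3)o2)cc1` differs from compound 3 in the group on the sulfonamide nitrogen (3-chloro-4-iodophenyl in place of 4-chloro-2-methylphenyl on a sulfonamide nitrogen) and the core stays the same. Among the compounds with values here, three measured steps bear on this, all changes to that same group: a step that the two limits leave unreadable from compound 1 to compound 2 and a step that the two limits leave unreadable from compound 1 to compound 3 and a step that the two limits leave unreadable from compound 2 to compound 3 have no size that can be read. They offer no number to carry over, and 3-chloro-4-iodophenyl appears in none of the three tested compounds. No step beyond the scatter is therefore expected in this assay and a reading at the same limit is the likeliest outcome. The estimated change is a number no higher from compound 3 to compound 4 (the limit leaves the size open) for now. Compound 4 is expected at 100000 nM with an estimated range of 40000 nM to 100000 nM in this test.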

Compound 4, concentration lethal to 50% of the cells: > 100000 nM
Compound 4 gave a limit, no number (the forecaster's own chance of this, stated with the estimate: 80%); the middle value lies on the limit itself.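

Within the data shown here, compound 4 also reads as a limit of the assay, not a number, so no step from compound 1, compound 2 or compound 3 to compound 4 can be read in this assay. The compounds shown leave open whether changing the group on the sulfonamide nitrogen alters this result at all, as the set offers only one reading: the limit of > 100000 nM in this assay, at which 4 of the 4 values shown sit.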